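The source may report more compounds than this note shows. Statements on the series, on what has been measured and on what is new or still open speak of the compounds shown alone.

Compounds measured so far:
compound 1, `O=C(Nc1cccc(Br)c1)N[C@@H]1C2CCN(CC2)[C@@H]1Cc1cccnc1`: > 10000 nM
compound 2, `CSc1ccc(NC(=O)N[C@@H]2C3CCN(CC3)[C@@H]2Cc2cccnc2)cc1`: > 10000 nM

Compound 2, `CSc1ccc(NC(=O)N[C@@H]2C3CCN(CC3)[C@@H]2Cc2cccnc2)cc1`, stands at the assay limit: in an assay on a protein complex for binding affinity to Neuronal acetylcholine receptor; alpha4/beta2 (Homo sapiens) (a higher number here means a weaker inhibitor, a lower number a stronger inhibitor), compound 2 gives > 10000 nM, which is a limit and not a number. Compound 1, `O=C(Nc1cccc(Br)c1)N[C@@H]1C2CCN(CC2)[C@@H]1Cc1cccnc1`, gives > 10000 nM in this assay, likewise a limit. For the measured compounds named here, the single measured step, a step that the two limits leave unreadable from compound 1 to compound 2, is therefore unreadable in size and direction; what the two values show is the limit of > 10000 nM in this assay, at which 2 of the 2 values shown sit.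

Compound 3, `O=C(Nc1ccc(F)cc1)N[C@@H]1C2CCN(CC2)[C@@H]1Cc1cccnc1`, differs from compound 2 by fluoro in place of methylsulfanyl on an aromatic carbon. Going by the values given here, no measured step bears on this change, and the one step offers no readable size to lean on. Since both measured compounds sit at the limit, the expectation for compound 3 is that it remains at the limit as well, a step that the limit leaves unreadable from compound 2 to compound 3 being expected, that is, no movement beyond the scatter. Compound 3 is estimated at 15000 nM, with a range from 4000 nM to 60000 nM.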

Compound 3, inhibition constant: > 10000 nM
Compound 3: no number, only a limit; the forecaster's own chance of this, stated with the estimate: 75%; the middle value does not contradict the limit.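

In this assay compound 3 gives > 10000 nM, which is a limit and not a number. The steps among compound 1, compound 2 and compound 3 therefore cannot be read, and no new step results: the limit of > 10000 nM in this assay, at which 3 of the 3 values shown sit.

The compounds shown leave open the actual affinity of all three and whether any aromatic substituent gives a value off the limit.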